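The source may hold more compounds than are shown below. What is called first, only, known or untested is meant among the compounds shown, and "the series" means these compounds.

In a functional assay on MCF7 cells (Homo sapiens) for cytotoxicity, read by MTT assay, with a stated time of 4 days (on this read-out higher numbers stand for weaker inhibition and lower numbers for stronger inhibition), compound 2 `C=C1C(=O)[C@]23C[C@@]1(O)CC[C@H]2c1ccc(OS(=O)(=O)c2ccc(C)cc2)c(C)c1[C@@H]3Cn1cc(-c2ccc(Cl)cc2)nn1` gives 1440 nM, the second highest of the three numbers. Compound 3 `C=C1C(=O)[C@]23C[C@@]1(O)CC[C@H]2c1ccc(O)c(C)c1[C@@H]3Cn1cc(-c2ccc(Cl)cc2)nn1` gives 2470 nM, and a 1.7-fold higher number from compound 2 to compound 3 (0.23 log units; within the scatter). Compound 1 `C=C1C(=O)[C@]23C[C@@]1(O)CC[C@H]2c1ccc(OS(=O)(=O)c2ccc(C)cc2)c(C)c1[C@@H]3Cn1cc(-c2ccc(Br)cc2)nn1` gives 250 nM. Compound 4 `C=C1C(=O)[C@]23C[C@@]1(O)CC[C@H]2c1ccc(OS(=O)(=O)c2ccc(C)cc2)c(C)c1[C@@H]3Cn1cc(-c2ccc(F)cc2)nn1` differs from compound 2 by fluoro in place of chloro on an aromatic carbon. Within the data shown here, the only measured step that bears on this is another change of halogen at an aromatic carbon, where a 5.8-fold higher number from compound 1 to compound 2 (0.76 log units; beyond the scatter). Among the measured compounds shown here, no step involving fluoro has been measured, so the direction rests on that single step alone, with wide uncertainty. Compound 4 is therefore expected to give a modestly higher number, a 2.1-fold higher number from compound 2 to compound 4 (0.32 log units; beyond the scatter), in this assay. The estimate for compound 4 is 3000 nM, with a range from 900 nM to 10000 nM.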

Compound 4, half-maximal inhibitory concentration: 330 nM
Beside the measured number, compound 4's estimate is 9.1-fold (0.96 log units) above it; measured number outside the range, below it.
By their numbers in this assay, from the lowest: compounds 1 and 4 (each within the scatter of the next); then compounds 2 and 3 (each within the scatter of the next).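

In this assay, fluoro in place of chloro gives a 4.4-fold lower number from compound 2 to compound 4 (0.64 log units; beyond the scatter), while fluoro in place of bromo gives a 1.3-fold higher number from compound 1 to compound 4 (0.12 log units; within the scatter). The halogens at this position therefore do not follow a steady trend from bromo through chloro to fluoro: the chloro compound 2 stands apart, while compound 1 and compound 4 cannot be told apart. Nothing available here explains this result. Still open, as far as these compounds go, is how an amine or a methoxy group would fare at this place, and whether losing the (4-methylphenyl)sulfonyl group would matter as little with bromo or fluoro.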